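A few compounds are considered here, and "the series" means these few. Any claim that something is new, unique, unknown or untested is made for them only; others in the source may bear on it.

Measured so far:
compound 1 `Cc1cc(NC(=O)Cn2nnc(-c3ccccc3)n2)n(C2CC2)n1` – > 78%
compound 2 `Cc1cc(NC(=O)Cn2nnc(-c3cccnc3)n2)n(C2CCCCC2)n1` – 96%

In an assay on HEK293 cells for activation of Kir3.1/Kir3.2 (Homo sapiens), read by thallium flux (on this read-out lower numbers stand for smaller maximal responses and higher numbers for larger maximal responses), compound 2 gives 96%. Among the measured compounds shown here, this is the only full number in hand; the one other result is a limit rather than a number. That other result belongs to compound 1, whose value in this assay of > 78% is a limit of the assay (the limit of > 78% in this assay, at which 1 of the 2 values shown sits). For the measured compounds named here, no step between measured compounds is therefore available, and what the two values show is simply that compound 2 reaches a large maximal response while compound 1 is reported only as a limit.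

Compound 3 `Cc1cc(NC(=O)Cn2nnc(C3CC3)n2)n(C2CCCCC2)n1` differs from compound 2 by cyclopropyl in place of pyridin-3-yl on an aromatic carbon. Without a measured step to draw on, the size of the change in this assay can only be guessed; a modest fall, or none beyond the scatter, seems most likely. Compound 3 is expected to give about 85%, with a range of 65% to 100%, which means an estimated step of a number 11 percentage points lower from compound 2 to compound 3 (beyond the scatter).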

Compound 3, largest response reached (Emax), in percent of the reference or control that the assay uses: > 68%
Compound 3: no number, only a limit (the forecaster's own chance of this, stated with the estimate: 20%); the middle value lies beyond the limit too.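

In this assay compound 3 gives > 68% as a limit of the assay and not a number. Among the compounds shown here, no step from compound 2 to compound 3 can be read from this result: the limit of > 68% in this assay, at which 1 of the 3 values shown sits.

Going by these compounds, whether cyclopropyl in place of pyridin-3-yl changes the maximal response, and by how much, stays open.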